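The source may hold more compounds than are shown below. What is called first, only, known or untested is meant among the compounds shown, and "the series" means these compounds.

Compound 1, `CC(C(=O)N1CCN(c2ccccc2)CC1)N1C(=O)CCC1=O`, is the simplest member of this small series: in a functional assay on the whole organism (strain Swiss) with Mus musculus as the target, in the maximal electroshock model, with a stated time of 2 h, at a dose of 300 mg/kg by the intraperitoneal route (a higher number here means a stronger effect of the compound at the dose given, a lower number a weaker effect), compound 1 gives 0%. Compound 2, `CC(C(=O)N1CCN(c2ccccc2F)CC1)N1C(=O)CCC1=O`, carries fluoro in place of hydrogen on an aromatic carbon, and in this assay compound 2 gives 25%. That single change produced a number 25 percentage points higher from compound 1 to compound 2 (beyond the scatter), a modest gain that is nevertheless beyond the scatter. Among the two numbers measured so far, compound 2 therefore stands highest, with compound 1 as its only neighbour, lower by a step beyond the scatter.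

Compound 3, `CC(C(=O)N1CCN(c2ccccc2C(F)(F)F)CC1)N1C(=O)CCC1=O`, goes one step further at the same place: trifluoromethyl in place of fluoro on an aromatic carbon. Among the measured compounds shown here, no measured pair shows what replacing fluoro with trifluoromethyl does here; the only step that bears on it is the one from hydrogen to fluoro, worth a number 25 percentage points higher from compound 1 to compound 2 (beyond the scatter), which suggests that a larger group at this carbon may be tolerated or even helpful. For the measured compounds named here, the step of a number 10 percentage points higher from compound 2 to compound 3 (within the scatter) is expected to be small and upward, though a result within the scatter would not surprise, because the one earlier change at this place gave a number 25 percentage points higher from compound 1 to compound 2 (beyond the scatter). For compound 3 the estimate in this assay is 35%, with a plausible range from 10% to 65%.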

Compound 3, a percentage reported as activity, at one dose (the size of the read-out at that dose, not a potency): 75%
Beside the measured number, compound 3's estimate is 40 percentage points below it; the whole stated range lies below it.
By their numbers in this assay, from the lowest: compound 1; then compound 2; then compound 3.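

The earlier step, hydrogen to fluoro, showed only that this aromatic carbon, ortho to a large group, responds modestly to substitution. In this assay, trifluoromethyl in place of fluoro gives a number 50 percentage points higher from compound 2 to compound 3 (beyond the scatter), a large step, so this position has far more to offer than the first change revealed, and replacing one fluorine atom with a group holding three does much more than the first substitution did. Set against the unsubstituted parent, trifluoromethyl gives a number 75 percentage points higher from compound 1 to compound 3 (beyond the scatter), also large and beyond the scatter, which makes compound 3 the clear leader of these three, although nothing available explains why this group has such an effect.

From the compounds shown here alone, with only hydrogen, fluoro and trifluoromethyl compared at this one carbon, it stays open whether the rise depends on fluorine itself, a question that a methyl or tert-butyl group, or a chlorine atom, could help to settle. Going by these compounds, it also stays open whether trifluoromethyl would do as well on another carbon of the same aromatic ring, and whether the gain would persist at other doses or times.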